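A Pyrimidine Ring in Place of Isopropyl on Piperazine

A few compounds are considered here, and "the series" means these few. Any claim that something is new, unique, unknown or untested is made for them only; others in the source may bear on it.

Of the compounds shown here, three sharing one core have been tested in a functional assay on DU-145 cells (Homo sapiens) for cytotoxicity, read by sulforhodamine B assay, with a stated time of 48 h; on this read-out higher numbers stand for weaker inhibition of growth and lower numbers for stronger inhibition of growth. Compound 1 `N#Cc1ccc(Nc2nc(Oc3ccnc4ccccc34)nc(N3CCCCC3)n2)cc1C(F)(F)F` gives 94900 nM in this assay. Compound 2 `COc1ccc(CN2CCN(c3nc(Nc4ccc(C#N)c(C(F)(F)F)c4)nc(Oc4ccnc5ccccc45)n3)CC2)c(OC)c1OC` reaches only the limit of this assay, > 100000 nM. Compound 3 `CC(C)N1CCN(c2nc(Nc3ccc(C#N)c(C(F)(F)F)c3)nc(Oc3ccnc4ccccc34)n2)CC1` likewise reaches only the limit of this assay, > 100000 nM, so it stands without a number of its own, and it is one of the two values sitting at that limit (the limit of > 100000 nM in this assay, at which 2 of the 3 values shown sit). Going by the values given here, the one measured step that can be compared, an at least 1.0-fold higher number from compound 1 to compound 3 (0.02 log units; that floor lies within the scatter), lies within the scatter.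

Compound 4 `N#Cc1ccc(Nc2nc(Oc3ccnc4ccccc34)nc(N3CCN(c4ncccn4)CC3)n2)cc1C(F)(F)F` differs from compound 3 in one place: pyrimidin-2-yl in place of isopropyl on an amine nitrogen in a ring. Among the compounds with values here, only the step from compound 1 to compound 3 bears on this change, and it shows nothing beyond the scatter; no measured step covers the pyrimidin-2-yl group itself. The step from compound 3 to compound 4 is therefore expected to be small, a number no higher from compound 3 to compound 4 (the limit leaves the size open), in no set direction. Compound 4 is expected to give about 100000 nM in this assay, somewhere from 30000 nM to 300000 nM, with a fair chance that only the limit is reported again.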

Compound 4, concentration for 50% growth inhibition: 85200 nM
Compound 4: middle estimate off by 1.2-fold (0.07 log units), on the high side, within the range that was stated.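

Replacing piperidin-1-yl with 4-(pyrimidin-2-yl)piperazin-1-yl in this assay gives a 1.1-fold lower number from compound 1 to compound 4 (0.05 log units; within the scatter) and so leaves compound 1 and compound 4 indistinguishable on this read-out. An aromatic ring on this amine nitrogen therefore still gives a measurable number, and the result adds no sign of stronger growth inhibition. Pyrimidin-2-yl in place of isopropyl gives an at least 1.1-fold lower number from compound 3 to compound 4 (0.06 log units; that floor lies within the scatter) and no more can be read from this step, because the value of compound 3 is a limit: the limit of > 100000 nM in this assay, at which 2 of the 4 values shown sit.

Going by these compounds, whether a plain phenyl ring, a carboxylic acid or a longer chain on this ring nitrogen would shift the number beyond the scatter remains open. Going by these compounds alone, it also remains open whether the two nitrogen atoms of pyrimidin-2-yl matter at all, as no compound here carries the same ring without them.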